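Dichloro aryl ureas: expected read-out for compound 3

The compounds below may be only part of what the source reports. "The series", "measured", "known", "first", "only" and "open" are said of these compounds alone.

Compound 1 `C[C@@H](NC(=O)Nc1ccccc1Cl)c1ccccc1` is one of two measured members of this series. In an ADME assay on the whole organism with Oryza sativa as the target, tested at 1 uM (on this read-out higher numbers stand for a weaker effect at the one concentration tested and lower numbers for a stronger effect), compound 1 gives 103%, and compound 2 `C[C@@H](NC(=O)Nc1cccc(Cl)c1Cl)c1ccccc1` gives 100%; the two numbers lie within the scatter of each other, so neither can be placed over the other. Within the data shown here, the only measured step, a number 3 percentage points lower from compound 1 to compound 2 (within the scatter), covers the entry of a chloro group on the shared core and shows no movement beyond the scatter.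

Compound 3 `C[C@@H](NC(=O)Nc1ccc(Cl)cc1Cl)c1ccccc1` is not yet measured. It differs from compound 1 by chloro in place of hydrogen on an aromatic carbon. The step from compound 1 to compound 2 is the only one that bears on this change, and it was within the scatter; on that basis no step beyond the scatter is expected for compound 3 in this assay, and the expected step is a number 2 percentage points lower from compound 1 to compound 3 (within the scatter). Compound 3 is therefore estimated at 101%, with a range from 91% to 111%.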

Compound 3, a percentage reported as activity, at one concentration (the size of the read-out at that concentration, not a potency): 99%
Estimate against measurement, compound 3: 2 percentage points above; the measured number falls inside the stated range.
By their numbers in this assay, from the lowest: compounds 3, 2 and 1 (each within the scatter of the next).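

In this assay, chloro in place of hydrogen on an aromatic carbon, meta to a chloro group and para to a large group, gives a number 4 percentage points lower from compound 1 to compound 3 (within the scatter) and so shows no movement beyond the scatter at this position. Among these compounds, this position now joins the one changed in a number 3 percentage points lower from compound 1 to compound 2 (within the scatter) as a second place where the entry of chloro on the core of compound 1 leaves the read-out within the scatter. No measured evidence bears on why this change leaves the read-out within the scatter.

As far as these compounds go, whether an amine, a methoxy group or a nitrile at this same position would give a step beyond the scatter remains open. Also open, from the compounds shown here alone, is whether a change elsewhere on the shared core, such as a longer chain in place of the methyl group, would shift the read-out.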